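The source may report more compounds than this note shows. Statements on the series, on what has been measured and on what is new or still open speak of the compounds shown alone.

For the measured compounds named here, in a functional assay on MCF7 cells (Homo sapiens) for inhibition (on this read-out lower numbers stand for stronger inhibition and higher numbers for weaker inhibition), compound 1 (`COc1c(C)cnc(CN2c3nc(N)nc(Cl)c3NC(=O)[C@@H]2C(C)C)c1C`) gives 1600 nM as the highest of the three numbers so far. Compound 2 (`COc1c(C)cnc(CN2CC(OC3CCCC3)=Nc3c(Cl)nc(N)nc32)c1C`) gives 40 nM and compound 3 (`COc1c(C)cnc(CN2c3nc(N)nc(Cl)c3N(C(C)C)C(=O)[C@@H]2C(C)C)c1C`) gives 40 nM and each of these two lies beyond the scatter from compound 1. Compound 4 (`COc1c(C)cnc(CN2c3nc(N)nc(Cl)c3NC(=O)[C@@H]2C)c1C`) is not yet measured. It differs from compound 1 by methyl in place of isopropyl on a saturated ring carbon. Going by the values given here, the one measured step that starts from compound 1 is a 40-fold lower number from compound 1 to compound 3 (1.60 log units; beyond the scatter) with isopropyl in place of hydrogen on an amide-type nitrogen in a ring. That step is large, but it lies at another place in the molecule, so its size cannot simply be carried over. Among the compounds with values here, it shows only that one small change on this core can move the number a long way in this assay and no measured pair tests the ring carbon group itself. A modest step toward a higher number is expected, estimated as a 2.5-fold higher number from compound 1 to compound 4 (0.40 log units; beyond the scatter) with real doubt about the direction. Compound 4 is estimated at 4000 nM with an expected range from 1000 nM to 16000 nM until its measurement is known.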

Compound 4, half-maximal inhibitory concentration: 940 nM
Beside the measured number, compound 4's estimate is 4.3-fold (0.63 log units) above it; measured number below the stated range.
By their numbers in this assay, from the lowest: compounds 2 and 3 (each within the scatter of the next); then compounds 4 and 1 (each within the scatter of the next).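

In this assay, the swap of isopropyl for methyl on the saturated ring carbon gives a 1.7-fold lower number from compound 1 to compound 4 (0.23 log units; within the scatter), so this assay does not separate these two groups at this position. For the compounds shown here, this is the first measured change at this ring carbon, and it contrasts with the change on the amide-type nitrogen, which gave a 40-fold lower number from compound 1 to compound 3 (1.60 log units; beyond the scatter). On the shared core, then, one position responds strongly to the change made there, while the other does not respond to this particular swap, and nothing measured offers an explanation for this result.

As far as these compounds go, whether an amine, a carboxylic acid or a longer chain on this ring carbon would leave the number just as unmoved remains open. Also open, from the compounds shown here alone, is whether methyl and isopropyl would still match with isopropyl on the amide-type nitrogen.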